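From a Chlorinated to a Methylated Benzyl Group

A few compounds are considered here, and "the series" means these few. Any claim that something is new, unique, unknown or untested is made for them only; others in the source may bear on it.

Within the data shown here, compound 2 `Cc1ccccc1Nc1nc(SCc2cn(Cc3ccccc3Cl)nn2)nc(-c2ccccc2)c1C#N` gives 2760 nM in a functional assay on B16-F10 cells (Mus musculus) for inhibition, read by MTT assay, with a stated time of 72 h (a higher number here means a weaker inhibitor, a lower number a stronger inhibitor), the lowest of the two numbers measured so far. Among the measured compounds shown here, its only measured neighbour, compound 1 `Cc1cccc(Nc2nc(SCc3cn(Cc4ccccc4Cl)nn3)nc(-c3ccccc3)c2C#N)c1`, gives 13500 nM, and the step of a 4.9-fold lower number from compound 1 to compound 2 (0.69 log units; beyond the scatter) arises from 2-methylphenyl in place of 3-methylphenyl on a nitrogen on an aromatic ring. Compound 3 `Cc1ccc(Cn2cc(CSc3nc(Nc4ccccc4C)c(C#N)c(-c4ccccc4)n3)nn2)cc1` has not been measured. It differs from compound 2 by 4-methylphenyl in place of 2-chlorophenyl on a saturated chain carbon bound to an aromatic nitrogen, that is, 2-chlorobenzyl to 4-methylbenzyl. For the measured compounds named here, no measured step touches this saturated chain carbon; the single known step concerns a different nitrogen and says nothing about this position. With no guidance from the measured pair, the expectation for compound 3 is a step of a 1.1-fold higher number from compound 2 to compound 3 (0.04 log units; within the scatter) that stays within the scatter, in no clear direction. Compound 3 is therefore estimated at 3000 nM, with a range from 900 nM to 10000 nM.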

Compound 3, half-maximal inhibitory concentration: > 64000 nM
Compound 3 ended at the assay's limit; the forecaster's own chance of this, stated with the estimate: 5%; at least 21-fold (1.32 log units) between middle value and limit.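

The saturated chain carbon bound to an aromatic nitrogen, which the earlier pair left untouched, turns out to be a sensitive place in this assay: the change from 2-chlorobenzyl to 4-methylbenzyl gives an at least 23-fold higher number from compound 2 to compound 3 (1.36 log units; beyond the scatter). For compound 3, the value > 64000 nM is a limit of the assay and not a number: the limit of > 64000 nM in this assay, at which 1 of the 3 values shown sits. The swap alters both the group on the ring and its place, from 2-chlorophenyl to 4-methylphenyl, and this single step cannot separate the two.

The compounds shown leave open how 2-methylbenzyl or 4-chlorobenzyl would behave here, and these two groups would show whether the atom or its place matters more. Also open, on these data alone, is whether a longer chain, such as 2-phenylethyl, would be tolerated at this carbon.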